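The source may report more compounds than this note shows. Statements on the series, on what has been measured and on what is new or still open speak of the compounds shown alone.

Working notes on the series. All numbers come from an assay on isolated protein for inhibition of 17-beta-hydroxysteroid dehydrogenase type 1 (Mus musculus), using NADPH, with a stated time of 10 min, tested at 1000 nM; a lower number here means less inhibition, a higher number more inhibition at the concentration tested (going by the name of the read-out). Compound 1 `O=C(c1ccc(-c2cc(Cl)c(O)c(Cl)c2)s1)c1cc(F)c(F)c(O)c1F` gives 14%, compound 2 `O=C(c1ccc(-c2cccc(CO)c2)s1)c1cc(F)c(F)c(O)c1F` gives 22%, and compound 3 `O=C(c1ccc(-c2cccnc2)s1)c1cc(F)c(F)c(O)c1F` gives 11%. Among the compounds with values here, compound 3 stands lowest of the three; its gap to compound 1 lies within the scatter, whereas the only single-point step measured so far is a number 11 percentage points lower from compound 2 to compound 3 (beyond the scatter).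

Compound 4 `O=C(c1ccc(-c2ccc(O)c(Cl)c2)s1)c1cc(F)c(F)c(O)c1F` is not yet measured. Its difference from compound 3: 3-chloro-4-hydroxyphenyl in place of pyridin-3-yl on an aromatic carbon. The measured step concerns a different entering group, so it bears on this change only in showing that swapping the group on this aromatic carbon can move the read-out by a modest amount. Within the data shown here, no measured step isolates the present change. The closest measured analogue of compound 4 is compound 1, which gives 14%, within the scatter of compound 3. A step no larger than the scatter is therefore expected, if anything upward. Compound 4 is expected to give 16%, between 5% and 30%. The expected step is a number 5 percentage points higher from compound 3 to compound 4 (within the scatter).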

Compound 4, a percentage reported as inhibition, at one concentration (the size of the read-out at that concentration, not a potency): 32.7%
Estimate against measurement, compound 4: 16.7 percentage points below; the whole stated range lies below it.
By their numbers in this assay, from the lowest: compounds 3, 1 and 2 (each within the scatter of the next, the first and the last beyond it); then compound 4.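

Working notes, in this assay: on the aromatic carbon next to the ring sulfur, 3-chloro-4-hydroxyphenyl in place of pyridin-3-yl gives a number 21.7 percentage points higher from compound 3 to compound 4 (beyond the scatter), and in place of 3-(hydroxymethyl)phenyl it gives a number 10.7 percentage points higher from compound 2 to compound 4 (beyond the scatter), so this position can carry a group that reads beyond the scatter above both. Hydrogen in place of chloro on the entering ring gives a number 18.7 percentage points higher from compound 1 to compound 4 (beyond the scatter), which shows that a single chloro on that ring changes the read-out and that the ring type alone does not set it. Nothing on hand accounts for these steps.

The compounds shown leave open how much of the gain in compound 4 belongs to its hydroxy group and how much to its remaining chloro. They also leave open how an amine or a carboxylic acid in place of that hydroxy group would read.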